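This account rests on a few compounds, and the source may have more. Where it says the series, first, only, none or still open, it means among the compounds named here.

Compound 1 `Cc1ccc(N2CCN(S(=O)(=O)c3ccc4c(c3)CC(=O)N4)CC2)cc1` is the starting point; in an assay on isolated protein for inhibition of lysosomal alpha-glucosidase (Homo sapiens), read by fluorescence, with stated times of 5 min and 45 min (on this read-out lower numbers stand for stronger inhibition and higher numbers for weaker inhibition), compound 1 is recorded as "not active" (no number reported), so no single number stands for it. Compound 2 `O=C1Cc2cc(S(=O)(=O)N3CCN(c4ccc(Cl)cc4)CC3)ccc2N1` sits close to it in structure, and in this assay compound 2 gives 94300 nM, which shows only weak inhibition. Compound 3 `O=C1Cc2cc(S(=O)(=O)N3CCN(c4ccc(Br)cc4)CC3)ccc2N1` has not yet been measured. Compound 3 differs from compound 1 by bromo in place of methyl on an aromatic carbon. Going by the values given here, no measured pair reports this change, so in this assay only a step within the usual scatter, in no clear direction, is expected. Compound 3 is estimated at 100000 nM, between 30000 nM and 300000 nM, and it may well be reported only as not active.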

Compound 3, half-maximal inhibitory concentration: "not active" (no number reported)
Nothing numeric was reported for compound 3, so the estimate cannot be set against anything.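

In this assay, compound 1 and compound 3 both stand without a number, so no step can be read between them. The compounds shown leave open how 4-methylphenyl to 4-bromophenyl affects inhibition. No other measurement bears on this result.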